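From 1-carboxyethyl to 1-carboxypropyl on the chloro compound

The source may hold more compounds than are shown below. What is called first, only, known or untested is meant among the compounds shown, and "the series" means these compounds.

Within the data shown here, in a physicochemical assay for lipophilicity, at pH 7.4 (on this read-out higher numbers stand for higher lipophilicity and lower numbers for lower lipophilicity), compound 1 `CC(C(=O)O)c1nn(Cc2cn3cc(OCC4CC4)c(Cl)cc3n2)c2ccccc2c1=O` gives 2.44, the lower of the two numbers so far. Compound 2 `CC(C(=O)O)c1nn(Cc2cn3cc(OCC4CC4)c(C(F)(F)F)cc3n2)c2ccccc2c1=O`, with trifluoromethyl in place of chloro on an aromatic carbon, gives 2.99. Compound 3 `CCC(C(=O)O)c1nn(Cc2cn3cc(OCC4CC4)c(Cl)cc3n2)c2ccccc2c1=O` keeps the chloro group and differs from compound 1 on the side chain: methyl in place of hydrogen on a saturated chain carbon, two bonds along the chain from an aromatic carbon and a carbonyl carbon. This is methyl in place of hydrogen on a saturated chain carbon, so methyl becomes ethyl. Among the measured compounds shown here, no step at this chain carbon has been measured. For the measured compounds named here, the only guide is a number 0.55 log units higher from compound 1 to compound 2 (beyond the scatter), and that change lies elsewhere on the molecule. A modest upward step of somewhat smaller size is therefore expected in this assay. The estimated step is a number 0.36 log units higher from compound 1 to compound 3 (beyond the scatter). Compound 3 is expected at 2.8, with an estimated range of 2.5 to 3.1.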

Compound 3, distribution coefficient: 2.71
Estimate against measurement, compound 3: 0.09 log units above, within the range that was stated.
By their numbers in this assay, from the lowest: compounds 1, 3 and 2 (each within the scatter of the next, the first and the last beyond it).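

In this assay, methyl in place of hydrogen on the saturated chain carbon, which turns 1-carboxyethyl into 1-carboxypropyl, gives a number 0.27 log units higher from compound 1 to compound 3 (within the scatter). Among these compounds, this is the first reading at this chain carbon, and it leaves the two compounds within the scatter of each other, whereas trifluoromethyl in place of chloro on the aromatic carbon gave a number 0.55 log units higher from compound 1 to compound 2 (beyond the scatter). No measurement on these compounds offers an explanation for either step.

As far as these compounds go, whether a longer chain such as 1-carboxybutyl, or a hydroxyl or an amine on this chain carbon, would give a step beyond the scatter remains open. Also open, from the compounds shown here alone, is whether methyl in place of hydrogen at this carbon gives a step of similar size on the trifluoromethyl compound 2, and a single step at this position supports no trend along the chain.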